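The source may hold more compounds than are shown below. What is called first, only, known or untested is meant among the compounds shown, and "the series" means these compounds.

Of the compounds shown here, three have been measured in a functional assay on SMMC-7721 cells (Homo sapiens) for cytotoxicity, read by MTT assay, with a stated time of 24 h; on this read-out higher numbers stand for weaker inhibition and lower numbers for stronger inhibition. Compound 2 `CN1C/C(=C\c2cccnc2)C(=O)/C(=C/c2ccccc2C(F)(F)F)C1` gives 3900 nM, and compound 1 `CN1C/C(=C\c2cccnc2)C(=O)/C(=C/c2ccccc2F)C1` gives 5420 nM; the change between them, (fluoro in place of trifluoromethyl on an aromatic carbon), made a 1.4-fold higher number from compound 2 to compound 1 (0.14 log units; within the scatter). Compound 3 `O=C1/C(=C/c2cccnc2)CN(S(=O)(=O)c2ccc(C(F)(F)F)cc2)C/C1=C\c1ccccc1F` gives 7900 nM; the difference between its core and the core of compound 2 is not broken down here. Compound 4 `O=C1/C(=C/c2cccnc2)CN(S(=O)(=O)c2ccc(F)cc2)C/C1=C\c1ccccc1F` has not yet been measured. It differs from compound 3 by fluoro in place of trifluoromethyl on an aromatic carbon, the same kind of change as that from compound 2 to compound 1, though there the group sits ortho to a large group and here para to a large group. Because the earlier step was a 1.4-fold higher number from compound 2 to compound 1 (0.14 log units; within the scatter) and lay within the scatter, a similar step is expected here, estimated at a 1.2-fold higher number from compound 3 to compound 4 (0.08 log units; within the scatter). Compound 4 is therefore expected to give about 9500 nM in this assay, most likely between 4500 nM and 20000 nM.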

Compound 4, half-maximal inhibitory concentration: 9900 nM
Compound 4: the middle estimate sits 1.0-fold (0.02 log units) below what was measured, within the range that was stated.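

In this assay, fluoro in place of trifluoromethyl gave a 1.3-fold higher number from compound 3 to compound 4 (0.10 log units; within the scatter), and the change behaved alike on the two cores: the same change on two cores in this assay, a 1.4-fold higher number (0.14 log units; within the scatter) from compound 2 to compound 1 and a 1.3-fold higher number (0.10 log units; within the scatter) from compound 3 to compound 4, 1.1-fold (0.04 log units) apart, within the scatter of two such steps. This shows that the step carried over between these two cores, but both steps lie within the scatter, and two pairs set no rule for other cores in the series. (4-Fluorophenyl)sulfonyl in place of methyl on the amine nitrogen in the ring gave a 1.8-fold higher number from compound 1 to compound 4 (0.26 log units; within the scatter), which also lies within the scatter.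

The compounds shown leave open what a methoxy, a nitrile or an amine would give in place of fluoro on the aromatic ring. They also leave open what an acetyl group or a longer alkyl chain would give on the amine nitrogen.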